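Replacing the acetyl on compound 2 with 1-hydroxyethyl

The source may hold more compounds than are shown below. What is called first, only, known or untested is meant among the compounds shown, and "the series" means these compounds.

Of the compounds shown here, two sharing one core have been measured in a functional assay on cells for agonist activity at Glucose-dependent insulinotropic receptor (Homo sapiens), read by a luciferase reporter, with a stated time of 4 h; on this read-out lower numbers stand for smaller maximal responses and higher numbers for larger maximal responses. Compound 1 `CS(=O)(=O)c1ccc2c(c1)CCN2c1ncnc2c(C3CCN(c4ncccn4)CC3)coc12` gives 196% in this assay. Among the measured compounds shown here, compound 2 `CC(=O)c1cnc(N2CCC(c3coc4c(N5CCc6cc(S(C)(=O)=O)ccc65)ncnc34)CC2)nc1` gives 12%, the lowest of the two numbers, with compound 1 as its only neighbour a large distance higher. For the measured compounds named here, the single measured step, a number 184 percentage points lower from compound 1 to compound 2 (beyond the scatter), shows that adding the acetyl to the aromatic carbon of the pyrimidine cut the maximal response drastically.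

Compound 3 `CC(O)c1cnc(N2CCC(c3coc4c(N5CCc6cc(S(C)(=O)=O)ccc65)ncnc34)CC2)nc1`, not yet measured, differs from compound 2 by 1-hydroxyethyl in place of acetyl on an aromatic carbon. Going by the values given here, no measured step covers this exact exchange; the only related information is the large drop from compound 1 to compound 2 when the acetyl entered. Since compound 3 keeps a substituent of the same size at that carbon but loses the double bond outside aromatic rings, the author expects a partial return toward the level of compound 1 rather than either extreme, with wide uncertainty. The step is expected to be a number 43 percentage points higher from compound 2 to compound 3 (beyond the scatter) in this assay. For compound 3 the expected value is 55%, within a range from 10% to 150%.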

Compound 3, largest response reached (Emax), in percent of the reference or control that the assay uses: 33%
Compound 3: the middle estimate sits 22 percentage points above what was measured; the measured number falls inside the stated range.
By their numbers in this assay, from the lowest: compound 2; then compound 3; then compound 1.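

In this assay, putting 1-hydroxyethyl in place of acetyl on this aromatic carbon gives a number 21 percentage points higher from compound 2 to compound 3 (beyond the scatter). The two groups have the same count of heavy atoms, so the response at this position depends on more than that count: it shifts when the double bond outside aromatic rings leaves and a hydrogen-bond donor enters. The shift is small, however, beside a number 163 percentage points lower from compound 1 to compound 3 (beyond the scatter), which shows that compound 3, like compound 2, remains far from compound 1, which carries hydrogen at this carbon; removing the carbonyl of the acetyl therefore does not by itself restore the large maximal response. Nothing measured here gives a reason for either step.

The compounds shown leave open whether any group at this carbon lowers the response so sharply, or whether a smaller one, such as methyl or fluorine, would stay closer to compound 1. They also leave open how an amine, a carboxylic acid or a longer chain carrying a hydroxyl would behave at this place.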